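Chloro for fluoro on the fused ring of compound 2

The source may report more compounds than this note shows. Statements on the series, on what has been measured and on what is new or still open speak of the compounds shown alone.

Two compounds of this series carry a measured value in a functional assay on the whole organism with Mus musculus as the target, with a stated time of 15 min; a higher number here means that more compound is needed for the effect, a lower number that less compound is needed. Compound 1 `Fc1sc2ccccc2c1C1NC=NC=C1Cl` gives 30 mg/kg in this assay, while compound 2 `Cc1sc2c(F)cccc2c1C1C=CN=CN1` gives 10 mg/kg. Compound 2 thus stands at the lower of the two numbers, and the gap to compound 1 lies beyond the scatter. Compound 3 `Cc1sc2c(Cl)cccc2c1C1C=CN=CN1` has not yet been measured in this assay. For the measured compounds named here, its single difference from compound 2 is chloro in place of fluoro on an aromatic carbon. Going by the values given here, no step of this exact kind is known, so the expectation rests on the closeness of the two halogens alone. The step of no change at the digits printed from compound 2 to compound 3 (within the scatter) is expected to stay within the scatter, in no preferred direction. Because compound 2 gives 10 mg/kg, compound 3 is estimated at 10 mg/kg, with a range from 5 mg/kg to 20 mg/kg in this assay.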

Compound 3, minimum effective dose: 30 mg/kg
Compound 3: middle estimate off by 3.0-fold (0.48 log units), on the low side; measured number outside the range, above it.
By their numbers in this assay, from the lowest: compound 2; then compounds 1 and 3 (each within the scatter of the next).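

In this assay, the two halogens are not interchangeable on this aromatic carbon of the six-membered ring: chloro in place of fluoro gives a 3.0-fold higher number from compound 2 to compound 3 (0.48 log units; beyond the scatter). For the compounds shown here, this is the first reading of a single change, as compound 1 and compound 2 differ in more than one place and so say nothing about this position alone. No measurement at hand accounts for the step, and its origin stays unexplained.

On these data alone, with only fluoro and chloro at this carbon, two points fix no trend, and it remains open how hydrogen, bromo, methoxy or a nitrile would read there. Also open, as far as these compounds go, is whether the same exchange would give a similar step on a core carrying other groups elsewhere.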